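Chain length and hydroxamate potency in A549 cells

This account rests on a few compounds, and the source may have more. Where it says the series, first, only, none or still open, it means among the compounds named here.

Compound 1 `Nc1nc2cc(-c3nn(CCC(=O)NO)c4ncnc(N)c34)ccc2o1`: > 150000 nM
Compound 2 `Nc1ncnc2c1c(-c1cnc3[nH]ccc3c1)nn2CCC(=O)NO`: > 150000 nM
Compound 3 `Nc1nc2cc(-c3nn(CC(=O)NO)c4ncnc(N)c34)ccc2o1`: 27700 nM

In a functional assay on A549 cells (Homo sapiens) for inhibition, read by MTT assay, with a stated time of 72 h (a higher number here means a weaker inhibitor, a lower number a stronger inhibitor), compound 3 gives 27700 nM. For compound 1 the value is only a limit of the assay, > 150000 nM. For compound 2 the value is likewise only a limit, > 150000 nM. The change from compound 3 to compound 1, ((hydroxycarbamoyl)methyl in place of hydroxycarbamoyl on a saturated chain carbon bound to an aromatic nitrogen), gives an at least 5.4-fold higher number from compound 3 to compound 1 (0.73 log units; beyond the scatter). The difference between the cores of compound 2 and compound 3 is not broken down here. Compound 4 `Nc1ncnc2c1c(-c1cnc3[nH]ccc3c1)nn2CCCC(=O)NO` carries the same kind of change, ((hydroxycarbamoyl)methyl in place of hydroxycarbamoyl on a saturated chain carbon, two bonds along the chain from an aromatic nitrogen), though here the place is two bonds along the chain from an aromatic nitrogen rather than bound to it. Because compound 2 already sits at the limit of > 150000 nM in this assay, at which 2 of the 3 values shown sit, and the earlier step weakened inhibition, compound 4 is expected to take a step that the limit leaves unreadable from compound 2 to compound 4. Compound 4 is estimated at 250000 nM, expected between 120000 nM and 600000 nM.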

Compound 4, half-maximal inhibitory concentration: > 150000 nM
Compound 4 ended at the assay's limit; the forecaster's own chance of this, stated with the estimate: 85%; the middle value is on the limit's open side.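

Compound 2 and compound 4 both stand at a limit of the assay, so no new step can be read between them: the limit of > 150000 nM in this assay, at which 3 of the 4 values shown sit.

Going by these compounds, how far the 2-(hydroxycarbamoyl)ethyl and 3-(hydroxycarbamoyl)propyl chains truly differ in this assay stays open.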